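This account rests on a few compounds, and the source may have more. Where it says the series, first, only, none or still open, it means among the compounds named here.

Compound 1 `CC(C)COc1ccc2c(Cl)ccnc2c1` at 2680 nM
Compound 2 `CCCCOc1ccc2c(Cl)ccnc2c1` at 3050 nM
Compound 3 `CCCCCCOc1ccc2c(Cl)ccnc2c1` not yet measured

All readings come from a functional assay on RKO cells (Homo sapiens) for cytotoxicity, read by MTT assay, with a stated time of 48 h (on this read-out lower numbers stand for stronger inhibition and higher numbers for weaker inhibition), and the two measured values lie within the scatter of each other, so compound 1 holds no real rank against compound 2. The next change, from compound 1 to compound 3, puts pentyl in place of isopropyl on a saturated chain carbon bound to an oxygen on an aromatic ring, counted as pentyl in place of isopropyl on a saturated chain carbon bound to an oxygen on an aromatic ring in this series. The same difference, cut one bond further out, reads isobutyl to hexyl. Going by the values given here, only one measured step bears on this, namely a 1.1-fold higher number from compound 1 to compound 2 (0.06 log units; within the scatter) for propyl in place of isopropyl at the same place, and it stays within the scatter. One such step is thin evidence, and no chain as long as that of compound 3 has been measured. No step beyond the scatter is therefore expected in this assay and no direction is favoured, with a wide margin kept. The expected change is a 1.0-fold higher number from compound 1 to compound 3 (0.02 log units; within the scatter) on this estimate. For compound 3 the estimated value is 2800 nM with an expected range from 1200 nM to 6500 nM once measured.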

Compound 3, half-maximal inhibitory concentration: 2720 nM
Compound 3: the middle estimate sits 1.0-fold (0.01 log units) above what was measured; the range from low to high includes it.
By their numbers in this assay, from the lowest: compounds 1, 3 and 2 (each within the scatter of the next).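

In this assay, the step to the longest chain shown, pentyl in place of isopropyl on a saturated chain carbon bound to an oxygen on an aromatic ring, gives a 1.0-fold higher number from compound 1 to compound 3 (0.01 log units; within the scatter), which extends the within-scatter reading of the earlier pair to a chain of this length. Ethyl in place of hydrogen on a saturated chain carbon, four bonds along the chain from an oxygen on an aromatic ring, gives a 1.1-fold lower number from compound 2 to compound 3 (0.05 log units; within the scatter), so the added chain length also fails to separate the two unbranched compounds, and the three compounds shown form a single group in this assay with no member ranked above another. No measurement on hand accounts for this reading.

On these data alone, whether a chain longer than hexyl, or a chain ending in an amine or a carboxylic acid, would give a step beyond the scatter at this position remains open. Also open is whether replacing the chlorine on the shared core with another group would give such a step, as every compound shown carries that atom.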